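Swapping a hydroxyphenyl for a styryl on the hydrazone

The compounds below may be only part of what the source reports. "The series", "measured", "known", "first", "only" and "open" are said of these compounds alone.

Two hydrazide-derived compounds built on a shared core have been tested in a functional assay on MCF7 cells (Homo sapiens) for cytotoxicity, read by MTT assay, with a stated time of 48 h; a lower number here means a stronger inhibitor, a higher number a weaker inhibitor. Compound 1 `NNC(=O)CSc1nnc(-c2ccncc2)o1` gives 3260 nM in this assay. Compound 2 `O=C(CSc1nnc(-c2ccncc2)o1)N/N=C/c1ccccc1O`, which carries a 2-hydroxyphenyl on the carbon double-bonded to nitrogen, gives 4750 nM in this assay. Among the measured compounds shown here, of the two numbers measured, compound 2 stands at the upper end, and its only neighbour, compound 1, sits within the usual scatter of it, so the two cannot be ranked.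

Compound 3 `O=C(CSc1nnc(-c2ccncc2)o1)N/N=C/C=C/c1ccccc1` has not yet been measured. It differs from compound 2 by 2-phenylethenyl in place of 2-hydroxyphenyl on a carbon with a double bond to nitrogen. For the measured compounds named here, no measured pair shows what such a swap does here, so the step from compound 2 to compound 3 is expected to be small, a 1.1-fold higher number from compound 2 to compound 3 (0.02 log units; within the scatter), with no clear direction beyond the scatter. On that basis compound 3 is expected to give about 5000 nM in this assay, most likely between 1500 nM and 16000 nM.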

Compound 3, half-maximal inhibitory concentration: 10800 nM
Compound 3: the middle estimate sits 2.2-fold (0.33 log units) below what was measured; measured number inside the range.
By their numbers in this assay, from the lowest: compounds 1 and 2 (each within the scatter of the next); then compound 3.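

In this assay the place on a carbon with a double bond to nitrogen turns out not to be indifferent to what sits on it: 2-phenylethenyl in place of 2-hydroxyphenyl gives a 2.3-fold higher number from compound 2 to compound 3 (0.36 log units; beyond the scatter) as a modest step. Among the compounds shown here, the earlier compounds offered no pair differing in one place, so this is the first change here that can be read. The swap removes a hydrogen-bond donor and acceptor and brings in a double bond outside aromatic rings, and nothing available tells which of these differences goes with the step.

A plain phenyl on the same carbon would help separate the loss of the hydroxyl from the added ethenyl link. On these data alone, how an amine or a carboxylic acid on the aromatic ring of this group would read also remains open.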